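This account rests on a few compounds, and the source may have more. Where it says the series, first, only, none or still open, it means among the compounds named here.

In an assay on cells for positive allosteric modulation of Cystic fibrosis transmembrane conductance regulator variant F508del (Homo sapiens), with stated times of 10 min and 7 s, in the presence of a further agent that is not named here (on this read-out higher numbers stand for an effect only at larger amounts of compound and lower numbers for an effect already at smaller amounts), compound 1 `CC1Cc2c(sc(NC(=O)c3ccccc3O)c2C(N)=O)C(C)O1` gives 4 nM, while compound 2 `CC1(C)Cc2c(sc(NC(=O)C(C)(C)O)c2C(N)=O)C(C)(C)O1` gives 16 nM. Compound 2 thus shows the higher of the two numbers, and its gap to compound 1 lies beyond the usual scatter. Compound 3 `Cc1n[nH]c(C(=O)Nc2sc3c(c2C(N)=O)CC(C)(C)OC3(C)C)c1Cl` differs from compound 2 in one place: a group of 7 heavy atoms (4 carbon, 2 nitrogen, 1 chlorine; one five-membered aromatic ring with 2 hetero atoms) in place of a group of 4 heavy atoms (3 carbon, 1 oxygen; no ring), on a carbonyl carbon. Because compound 1, which also carries an aromatic ring at the amide, gives 4 nM, a moderate step toward lower numbers is expected from compound 2 to compound 3 a 2.0-fold lower number from compound 2 to compound 3 (0.30 log units; within the scatter). Compound 3 is therefore estimated at 8 nM, within a range from 3 nM to 25 nM.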

Compound 3, half-maximal effective concentration: 11 nM
Beside the measured number, compound 3's estimate is 1.4-fold (0.14 log units) below it, and the stated range covers the measured number.
By their numbers in this assay, from the lowest: compound 1; then compounds 3 and 2 (each within the scatter of the next).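

On the carbonyl carbon, putting the five-membered aromatic ring with 2 hetero atoms in place of the 1-hydroxy-1-methylethyl group gives, in this assay, a 1.5-fold lower number from compound 2 to compound 3 (0.16 log units; within the scatter) and so shows that this position takes either the open-chain group or the larger ring group without a change that stands out from the scatter. The two groups hold the same counts of hydrogen-bond donors and acceptors. Nothing measured here explains why their numbers lie so close. Still open, from the compounds shown here alone, is how an amine or a carboxylic acid would read on this carbonyl carbon. Also open is what the ring's chlorine contributes, as would be shown by a ring with hydrogen in its place.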